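The source may hold more compounds than are shown below. What is called first, only, known or untested is meant among the compounds shown, and "the series" means these compounds.

Two hydroxamic acids built on the same core have been measured. Compound 1 `Cc1cccc(CN2CCC=C(CCC(=O)NO)C2=O)c1` carries a methyl-substituted benzyl group on the ring nitrogen, and in a functional assay on ACHN cells (Homo sapiens) for inhibition, read by sulforhodamine B assay (on this read-out lower numbers stand for stronger inhibition of growth and higher numbers for weaker inhibition of growth), compound 1 gives 4380 nM. Compound 2 `O=C(CCC1=CCCN(Cc2ccc([N+](=O)[O-])cc2)C1=O)NO` carries a nitro-substituted benzyl group instead, and in this assay compound 2 gives 5210 nM. Compound 2 stands at the higher of the two numbers, but its nearest neighbour, compound 1, lies within the scatter of it, so the two cannot be told apart on this read-out.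

Compound 3 `O=C(CCC1=CCCN(Cc2ccc(Br)cc2)C1=O)NO` has not yet been measured in this assay. It differs from compound 2 in one place: bromo in place of nitro on an aromatic carbon. For the measured compounds named here, no pair of measured compounds shows a step of this kind, so the expected size of the change rests only on the two values at hand, which lie close to each other. On that basis the step from compound 2 to compound 3 is expected to be none beyond the scatter, a 1.2-fold lower number from compound 2 to compound 3 (0.06 log units; within the scatter). Compound 3 is therefore estimated to give 4500 nM in this assay, with a range from 2000 nM to 10000 nM.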

Compound 3, concentration for 50% growth inhibition: 2480 nM
Beside the measured number, compound 3's estimate is 1.8-fold (0.26 log units) above it, within the range that was stated.
By their numbers in this assay, from the lowest: compounds 3, 1 and 2 (each within the scatter of the next, the first and the last beyond it).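

In this assay, for the compounds shown here, bromo in place of nitro on this aromatic carbon, para to a large group, gives a 2.1-fold lower number from compound 2 to compound 3 (0.32 log units; beyond the scatter), the first step in this set that stands clear of the scatter. The group at this place therefore has a small but readable bearing on the number, which the two earlier compounds could not show, although the step to compound 3 is only just large enough to be read. The second step, a 1.8-fold lower number from compound 1 to compound 3 (0.25 log units; within the scatter), shows that 4-bromophenyl in place of 3-methylphenyl cannot be told from no change, so compound 3 is set apart from compound 2 but not from compound 1, and the data offer no independent measurement that would account for the step from nitro to bromo.

As far as these compounds go, whether other groups at this place, such as chloro, methoxy or an amine, would extend the step or leave the number within the scatter remains open. So does whether the step from nitro to bromo would hold on a shared core with a longer chain leading to the hydroxamic acid.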